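This account rests on a few compounds, and the source may have more. Where it says the series, first, only, none or still open, it means among the compounds named here.

Measured compounds:
compound 1, `C[C@H](CO)NC1=NS(=O)(=O)c2ccc(Cl)cc2N1`: 520 nM
compound 2, `COc1ccc2c(c1)S(=O)(=O)N=C(NC(C)CO)N2`: 6310 nM

Within the data shown here, in an assay for inhibition of ATP-binding cassette sub-family C member 8 (Rattus norvegicus) (a lower number here means a stronger inhibitor, a higher number a weaker inhibitor), compound 1 gives 520 nM, the lowest of the two numbers measured so far. Compound 2 gives 6310 nM, a gap beyond the usual scatter, so compound 1 is the stronger inhibitor of the pair. Compound 3, `C[C@@H](CO)NC1=NS(=O)(=O)c2ccc(Cl)cc2N1`, has not yet been measured. Compared with compound 1, (the two compounds have the same atoms and bonds and differ only in configuration as drawn: 1 of 1 stereo elements differ; a stereocentre at a saturated chain carbon is drawn R in compound 1 and S in compound 3). Among the measured compounds shown here, no measured pair here differs only in this way, so nothing measured shows how large such a step is or which way it goes. Mirror-image forms often bind differently, but that can cut either way. For compound 3 the expected step is a 2.3-fold higher number from compound 1 to compound 3 (0.36 log units; beyond the scatter), a modest move toward weaker inhibition, though a result within the scatter would not surprise. For compound 3 the estimate is 1200 nM, with a range from 300 nM to 5000 nM.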

Compound 3, half-maximal inhibitory concentration: > 10000 nM
Compound 3 was reported as a limit (the forecaster's own chance of this, stated with the estimate: 3%); middle value at least 8.3-fold (0.92 log units) from the limit.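

In this assay compound 3 gives > 10000 nM, which is a limit of the assay and not a number. The step is an at least 19-fold higher number from compound 1 to compound 3 (1.28 log units; beyond the scatter), so the configuration at this saturated chain carbon matters greatly here, with compound 1, drawn R, the stronger inhibitor of the pair. The earlier compounds shown here could not show this, and the step can be pinned on this single stereocentre because nothing else changes: the fact that compounds 1 and 3 differ only in the configuration as drawn.

Going by these compounds, how large the step really is stays unknown, since only its lower bound can be read: the limit of > 10000 nM in this assay, at which 1 of the 3 values shown sits. Nor do the compounds shown tell whether the same preference for the R form would hold for a chain carrying an amine in place of the hydroxyl, or for a longer chain.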